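Shortening a Propyl Tail in a Cinnamamide Series

The source may hold more compounds than are shown below. What is called first, only, known or untested is meant among the compounds shown, and "the series" means these compounds.

Measured compounds:
compound 1 `CCCc1ccc(/C=C/C(=O)Nc2ccc3nc(CCC)cc(N)c3c2)cc1` — 3600 nM
compound 2 `Nc1cc(C2CCCC2)nc2ccc(NC(=O)/C=C/c3ccc(C(F)(F)F)cc3)cc12` — 68 nM
compound 3 `CCCc1cc(NC2CCC2)c2cc(NC(=O)/C=C/c3ccc(C(F)(F)F)cc3)ccc2n1` — 270 nM

All three compounds were tested in a functional assay on HEK293 cells for activation of melanin-concentrating hormone receptor 1 (Homo sapiens), read by inositol phosphate accumulation; a higher number here means that more compound is needed for the effect, a lower number that less compound is needed. Compound 1 stands at the top of these numbers with 3600 nM. Its nearest neighbour is compound 3, which gives 270 nM, a gap that lies beyond the usual scatter. Compound 2 gives 68 nM, still further away. Compounds 2 and 3 both carry a trifluoromethyl group on the phenyl ring and differ from compound 1 at the core as well, so neither isolates any single change.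

Among the compounds with values here, compound 4 `CCCc1cc(N)c2cc(NC(=O)/C=C/c3ccc(CC)cc3)ccc2n1` keeps the core of compound 1 and the same amide linker; the only change is hydrogen in place of methyl on a saturated chain carbon, two bonds along the chain from an aromatic carbon. Within the data shown here, no measured pair in this set shows that change on its own, so there is no direct precedent for its size. Because compound 1 gives 3600 nM and compound 4 differs from it only by hydrogen in place of methyl, the shift in this assay is expected to be small, most likely within the scatter, and if anything slightly toward a lower number, giving a 1.4-fold lower number from compound 1 to compound 4 (0.16 log units; within the scatter). Compound 4 is therefore estimated at 2500 nM, with a range from 900 nM to 7000 nM.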

Compound 4, half-maximal effective concentration: 160 nM
Compound 4: middle estimate off by 16-fold (1.19 log units), on the high side; measured number below the stated range.
By their numbers in this assay, from the lowest: compound 2; then compounds 4 and 3 (each within the scatter of the next); then compound 1.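

Replacing the 4-propylphenyl group of compound 1 with 4-ethylphenyl, while the shared core and amide linker stay the same, gives a 23-fold lower number from compound 1 to compound 4 (1.35 log units; beyond the scatter) in this assay for this one change. Within the data shown here, this is the first pair in the set that differs in only one place, and it shows that the saturated chain carbon two bonds along from the aromatic carbon is far from a silent position, since removing one carbon, with no ring, hydrogen-bond donor, hydrogen-bond acceptor or net charge involved, moves the number well beyond the scatter. Nothing measured here accounts for a step of this size.

A single step cannot show whether the number keeps falling as the chain shortens further to 4-methylphenyl, whether it rises again with a longer chain such as 4-butylphenyl, or whether a branched chain such as 4-isopropylphenyl behaves like either one. It also leaves open whether the same shortening has a comparable effect on a different core, or when the amine on the core of compound 1 is replaced by a cyclobutylamine.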